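The source may report more compounds than this note shows. Statements on the series, on what has been measured and on what is new or still open speak of the compounds shown alone.

Cytotoxicity series, read in an ADME assay on Vero cells (Chlorocebus sabaeus) for cytotoxicity, read by MTT assay, with a stated time of 72 h; on this read-out higher numbers stand for weaker inhibition and lower numbers for stronger inhibition.

Measured:
compound 1 `CCOC(=O)c1c(C(F)(F)F)[n+]([O-])c2cc(-n3ccnc3)c(F)cc2[n+]1[O-]` gives 19400 nM
compound 2 `CCOC(=O)c1c(C(F)(F)F)[n+]([O-])c2cc(-n3cncn3)c(F)cc2[n+]1[O-]` gives 35400 nM
compound 3 `Cc1c(C(=O)OCc2ccccc2)[n+]([O-])c2cc(F)c(-n3ccnc3)cc2[n+]1[O-]` gives 107000 nM

Compound 1 and compound 2 share one core and differ only by 1H-1,2,4-triazol-1-yl in place of 1H-imidazol-1-yl on an aromatic carbon; that change gave a 1.8-fold higher number from compound 1 to compound 2 (0.26 log units; within the scatter). Compound 3 carries a different core; the difference between the two cores is not broken down here. In this assay compound 3 has the highest of the three numbers, beyond the scatter from both others.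

Compound 4 `Cc1c(C(=O)OCc2ccccc2)[n+]([O-])c2cc(F)c(-n3cncn3)cc2[n+]1[O-]` is not yet measured. It differs from compound 3 by 1H-1,2,4-triazol-1-yl in place of 1H-imidazol-1-yl on an aromatic carbon, the same change, at the same place, as from compound 1 to compound 2. For the measured compounds named here, a step of similar size is expected, a 1.5-fold higher number from compound 3 to compound 4 (0.17 log units; within the scatter), because the single precedent gave a 1.8-fold higher number from compound 1 to compound 2 (0.26 log units; within the scatter); the core of compound 3 gives no further guidance. Compound 4 is estimated at 160000 nM, likely between 70000 nM and 400000 nM.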

Compound 4, half-maximal inhibitory concentration: 123000 nM
Beside the measured number, compound 4's estimate is 1.3-fold (0.11 log units) above it, within the range that was stated.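

In this assay, 1H-1,2,4-triazol-1-yl in place of 1H-imidazol-1-yl gave a 1.1-fold higher number from compound 3 to compound 4 (0.06 log units; within the scatter). Set beside the earlier step, the change gives steps on the two cores that cannot be told apart: the same change on two cores in this assay, a 1.8-fold higher number (0.26 log units; within the scatter) from compound 1 to compound 2 and a 1.1-fold higher number (0.06 log units; within the scatter) from compound 3 to compound 4, 1.6-fold (0.20 log units) apart, within the scatter of two such steps. Both steps lie within the scatter, so the swap shows no measurable effect on either core; this does not establish a true size or direction for the change, and two cores cannot show that it would behave the same way on every core in the series.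

On these data alone, whether the same holds on a third core remains open. Also open, as far as these compounds go, is whether an amine or a carboxylic acid in place of the five-membered aromatic ring would shift the number beyond the scatter.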